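The source may hold more compounds than are shown below. What is called first, only, known or untested is meant among the compounds shown, and "the series" means these compounds.

Series notes. Within the data shown here, compound 1 `COc1cc2sc(Nc3ccccc3)c(C#N)c2cc1OC` stands at the top of the two numbers measured so far in a functional assay on HUVEC cells (Homo sapiens), read by fluorescence and microscopy, with a stated time of 6 h, tested at 10 uM; a higher number here means a weaker effect of the compound at the concentration tested, a lower number a stronger effect: in this assay compound 1 gives 77%. Its nearest neighbour is compound 2 `COc1ccc(Nc2sc3ccccc3c2C#N)cc1`, which in this assay gives 57%, a gap beyond the scatter; the two structures differ in more than one place, so the gap cannot be assigned to a single change. The step followed here leads from compound 1 to compound 3 `COc1cc2sc(Nc3cccc(O)c3)c(C#N)c2cc1OC`, not yet measured. The difference is hydroxy in place of hydrogen on an aromatic carbon, the new group sitting on an aromatic carbon of the six-membered aromatic ring of carbon only, meta to a large group. Among the measured compounds shown here, no measured pair isolates this change, so its effect in this assay is unknown. The step from compound 1 to compound 3 is expected to be small, likely within the scatter, with a slight lean toward a lower number, a number 7 percentage points lower from compound 1 to compound 3 (within the scatter). Compound 3 is estimated at 70%, within 45% to 95%.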

Compound 3, a percentage reported as activity, at one concentration (the size of the read-out at that concentration, not a potency): 11%
Estimate against measurement, compound 3: 59 percentage points above; the whole stated range lies above it.
By their numbers in this assay, from the lowest: compound 3; then compound 2; then compound 1.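

In this assay the change from phenyl to 3-hydroxyphenyl now stands alone as a single difference, and it gives a number 66 percentage points lower from compound 1 to compound 3 (beyond the scatter). This aromatic carbon, meta to a large group, is therefore a place in the series where one added hydroxy group is enough for a large step on the core of compound 1. No measurement on hand offers an explanation for the size of this step.

As far as these compounds go, whether the step is specific to hydroxy remains open: an amine or a carboxylic acid on the same carbon would test that. Also open, from the compounds shown here alone, is whether hydroxy on other carbons of this ring, or on the core of compound 2, would give a step of similar size.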